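Extending the side chain of compound 3

The source may hold more compounds than are shown below. What is called first, only, known or untested is meant among the compounds shown, and "the series" means these compounds.

In an ADME assay on cells (Peritoneal macrophage, Mus musculus) for cytotoxicity, read by CCK-8 assay, with a stated time of 24 h (on this read-out higher numbers stand for lower toxicity in this test and lower numbers for higher toxicity in this test), compound 1 (`COc1ccc(S(=O)(=O)N(CC(N)=O)c2ccc(N(CC(N)=O)S(=O)(=O)c3ccc(SCCN=C=S)cc3)c3ccccc23)cc1`) gives > 10000 nM, a limit of the test and not a number. Compound 2 (`COc1ccc(S(=O)(=O)N(CC(N)=O)c2ccc(N(CC(N)=O)S(=O)(=O)c3ccc(SCCCCCN=C=S)cc3)c3ccccc23)cc1`) gives > 10000 nM, also a limit. Compound 3 (`COc1ccc(S(=O)(=O)N(CC(N)=O)c2ccc(N(CC(N)=O)S(=O)(=O)c3ccc([S+]([O-])CCCCN=C=S)cc3)c3ccccc23)cc1`) gives > 10000 nM, again a limit. All three stand together: the limit of > 10000 nM in this assay, at which 3 of the 3 values shown sit. Compound 4 (`COc1ccc(S(=O)(=O)N(CC(N)=O)c2ccc(N(CC(N)=O)S(=O)(=O)c3ccc([S+]([O-])CCCCCN=C=S)cc3)c3ccccc23)cc1`) differs from compound 3 by one change: a group of 4 heavy atoms (2 carbon, 1 nitrogen, 1 sulfur; no ring) in place of a group of 3 heavy atoms (1 carbon, 1 nitrogen, 1 sulfur; no ring), on a saturated chain carbon, four bonds along the chain from a sulfur. For the measured compounds named here, the closest precedent for a longer chain is a step that the two limits leave unreadable from compound 1 to compound 2. The other two measured changes are a step that the two limits leave unreadable from compound 1 to compound 3 and a step that the two limits leave unreadable from compound 2 to compound 3. None of these has a readable size, so no step beyond the scatter is expected, and the expected change is a step that the limit leaves unreadable from compound 3 to compound 4. Compound 4 is estimated at 15000 nM, with an expected range of 7000 nM to 30000 nM.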

Compound 4, half-maximal cytotoxic concentration: > 10000 nM
Compound 4: only a limit was reported; the forecaster's own chance of this, stated with the estimate: 90%; the middle value is on the limit's open side.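

The steps from compound 1, compound 2 and compound 3 to compound 4 cannot be read in this assay, since all four values are limits: the limit of > 10000 nM in this assay, at which 4 of the 4 values shown sit.

As far as these compounds go, how far each compound's true value lies past that limit, and whether the longer chain of compound 4 changes it, stays open.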